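This account rests on a few compounds, and the source may have more. Where it says the series, first, only, none or still open, it means among the compounds named here.

The compounds measured so far, with their values in a functional assay on the whole organism for inhibition, with Mythimna separata as the target, with a stated time of 5 days; on this read-out lower numbers stand for an effect already at smaller amounts and higher numbers for an effect only at larger amounts of compound:

Compound 1, `CC(C)(C)n1ncc(OCc2nnc(-c3ccccc3Cl)o2)c(Cl)c1=O`: compound 1 gives 61200 nM.
Compound 2, `Cc1ccc(-c2nnc(COc3cnn(C(C)(C)C)c(=O)c3Cl)o2)cc1`: compound 2 gives 19900 nM.
Compound 3, `Cc1cc(C)cc(-c2nnc(COc3cnn(C(C)(C)C)c(=O)c3Cl)o2)c1`: compound 3 reached only a limit of the assay, > 299000 nM.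

Compound 3 thus stands at the weak end of the three, and its number is not known exactly: the limit of > 299000 nM in this assay, at which 1 of the 3 values shown sits. The two steps that lead to it were both upward, an at least 4.8-fold higher number from compound 1 to compound 3 (0.68 log units; beyond the scatter) and an at least 15-fold higher number from compound 2 to compound 3 (1.17 log units; beyond the scatter), while the change between the other two aryl groups was smaller, a 3.1-fold lower number from compound 1 to compound 2 (0.49 log units; beyond the scatter). Compound 4, `CC(C)(C)n1ncc(OCc2nnc(-c3cccc(F)c3)o2)c(Cl)c1=O`, has not been measured yet. It differs from compound 3 in one place: 3-fluorophenyl in place of 3,5-dimethylphenyl on an aromatic carbon. Within the data shown here, no measured step involves a fluorine on the phenyl ring, so the comparison rests on the fact that the two compounds with a smaller aryl group, compound 1 and compound 2, both gave a number rather than a limit. Compound 4 is therefore expected to show a lower number than compound 3, a step of about an at least 4.9-fold lower number from compound 3 to compound 4 (0.69 log units; beyond the scatter), with considerable uncertainty. The estimate for compound 4 in this assay is 60000 nM, within a range from 15000 nM to 250000 nM.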

Compound 4, half-maximal effective concentration: 7100 nM
Compound 4: middle estimate off by 8.5-fold (0.93 log units), on the high side, outside the stated range (below it).
By their numbers in this assay, from the lowest: compound 4; then compound 2; then compound 1. At a limit, above all of these: compound 3.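

In this assay, this aryl position on the five-membered ring is not closed to substituted phenyl groups: 3-fluorophenyl in place of 3,5-dimethylphenyl restores a measurable effect, with an at least 42-fold lower number from compound 3 to compound 4 (1.62 log units; beyond the scatter). The fluorinated compound also goes beyond the two earlier groups that gave numbers, with a 2.8-fold lower number from compound 2 to compound 4 (0.45 log units; beyond the scatter) and an 8.6-fold lower number from compound 1 to compound 4 (0.94 log units; beyond the scatter), so the change does more than avoid the loss seen with 3,5-dimethylphenyl, and compound 4 has the lowest number of the four. Compound 3 remains a limit rather than a number, so the first of these steps gives only a minimum size: the limit of > 299000 nM in this assay, at which 1 of the 4 values shown sits.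

The compounds shown do not separate the effect of fluorine from the effect of where a group sits on the phenyl ring, as no two of them carry the same substituent at different places. Also open, on these data alone, is what a 3-chlorophenyl group, a methoxy group or a carboxylic acid on that ring would give, and whether an unsubstituted phenyl group would sit above or below these values.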